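Amine-substituent change at the anilino nitrogen: compound 3

The compounds below may be only part of what the source reports. "The series", "measured", "known", "first", "only" and "open" are said of these compounds alone.

In a functional assay on the whole organism for inhibition, with Rattus norvegicus as the target, read by paw edema, with stated times of 1 h and 6 h, at a dose of 0.03 mg/kg by the oral route (a higher number here means more inhibition at the dose given (going by the name of the read-out), a lower number less inhibition), compound 1 `CC1=NN(C(=O)c2cc3ccccc3oc2=O)C(=O)C1CNc1ccc(Cl)cc1` gives 71.5% and compound 2 `CC1=NN(C(=O)c2cc3ccccc3oc2=O)C(=O)C1CNc1ccc(O)c(C(=O)O)c1` gives 50.9%, the lower of the two numbers. Going by the values given here, the one measured step at this position, a number 20.6 percentage points lower from compound 1 to compound 2 (beyond the scatter), is the only guide here. Compound 3 `COc1ccc(NCC2C(=O)N(C(=O)c3cc4ccccc4oc3=O)N=C2C)cc1` carries the change (4-methoxyphenyl in place of 3-carboxy-4-hydroxyphenyl on an amine nitrogen). Among the compounds with values here, this reverses the direction of the single step rather than extending it, since compound 1 holds a substituent without those donors and gave the higher number, so a rise is expected, roughly a number 14.1 percentage points higher from compound 2 to compound 3 (beyond the scatter). Compound 3 is therefore estimated at 65%, with a range from 48% to 80%.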

Compound 3, a percentage reported as inhibition, in the whole organism at one dose (the size of the read-out at that dose, not a potency): 55.1%
For compound 3 the middle estimate is 9.9 percentage points above the measured one; the measured number falls inside the stated range.
By their numbers in this assay, from the lowest: compounds 2 and 3 (each within the scatter of the next); then compound 1.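

In this assay 4-methoxyphenyl in place of 3-carboxy-4-hydroxyphenyl on the amine nitrogen gives a number 4.2 percentage points higher from compound 2 to compound 3 (within the scatter) and so does not separate these two substituents. Methoxy in place of chloro on the aromatic carbon gives a number 16.4 percentage points lower from compound 1 to compound 3 (beyond the scatter) and so leaves the 4-chlorophenyl of compound 1 apart from both other substituents. Nothing available here explains these numbers.

Open, going by these compounds, is whether the chloro itself matters: a fluoro, bromo or methyl on that aromatic carbon could fall with compound 1 or with compound 2 and compound 3.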